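Heteroaryl ether variation on the cyclohexyl oxygen

The source may report more compounds than this note shows. Statements on the series, on what has been measured and on what is new or still open speak of the compounds shown alone.

For the measured compounds named here, compound 2 `CC(C)(C)C#Cc1cc(N(C(=O)[C@H]2CC[C@H](C)CC2)[C@H]2CC[C@H](Oc3ccc(=O)[nH]n3)CC2)c(C(=O)O)s1` gives 2 in a physicochemical assay for lipophilicity (on this read-out lower numbers stand for lower lipophilicity and higher numbers for higher lipophilicity), the lowest of the two numbers so far; compound 1 `CC(C)(C)C#Cc1cc(N(C(=O)[C@H]2CC[C@H](C)CC2)[C@H]2CC[C@H](Oc3ccc4nccn4n3)CC2)c(C(=O)O)s1` gives 2.4. Compound 3 `CC(C)(C)C#Cc1cc(N(C(=O)[C@H]2CC[C@H](C)CC2)[C@H]2CC[C@H](Oc3ccncn3)CC2)c(C(=O)O)s1` differs from compound 2 by a group of 6 heavy atoms (4 carbon, 2 nitrogen; one six-membered aromatic ring with 2 hetero atoms) in place of a group of 7 heavy atoms (4 carbon, 2 nitrogen, 1 oxygen; one six-membered aromatic ring with 2 hetero atoms), on an oxygen on a saturated carbon. Going by the values given here, the only step at this position, a number 0.40 log units lower from compound 1 to compound 2 (beyond the scatter), shows that swapping the aromatic group on this oxygen moves this assay modestly. Since the entering pyrimidin-4-yl carries no hydrogen-bond donor where the leaving group had one, a modest rise is expected, a number 0.40 log units higher from compound 2 to compound 3 (beyond the scatter). Compound 3 is therefore estimated at 2.4, with a range from 1.9 to 2.9.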

Compound 3, distribution coefficient: 2.3
The estimate for compound 3 lay 0.10 log units above the measured number; the range from low to high includes it.
By their numbers in this assay, from the lowest: compounds 2, 3 and 1 (each within the scatter of the next, the first and the last beyond it).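

With pyrimidin-4-yl on the oxygen, this assay gives a number 0.30 log units higher from compound 2 to compound 3 (within the scatter) and a number 0.10 log units lower from compound 1 to compound 3 (within the scatter), so this group is not separated from either earlier group. For the compounds shown here, the only step beyond the scatter remains a number 0.40 log units lower from compound 1 to compound 2 (beyond the scatter), and removing the hydrogen-bond donor of the leaving group produces no step beyond the scatter here. No available evidence explains these numbers. Still open, from the compounds shown here alone, is how this assay responds to a plain phenyl ring on this oxygen, or to an aromatic group carrying an amine or a carboxylic acid.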